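Aryl swap on the enone chain: compound 2 to compound 4

This account rests on a few compounds, and the source may have more. Where it says the series, first, only, none or still open, it means among the compounds named here.

Three members of the series have been measured in a functional assay on NCI-H727 cells (Homo sapiens), read by fluorescence and BrdU incorporation, with a stated time of 48 h, tested at 10 uM; on this read-out higher numbers stand for a weaker effect at the one concentration tested and lower numbers for a stronger effect. Compound 1 `COc1cc(OC)c(C(=O)/C=C/c2ccccc2SC)c(OC)c1` gives 35% in this assay. Compound 2 `COc1cccc(/C=C/C(=O)c2c(OC)cc(OC)cc2OC)c1` gives 37% in this assay. Compound 3 `COc1cc(O)c(C(=O)/C=C/c2ccccc2OC)c(OC)c1` gives 43% in this assay. On these three numbers compound 2 sits in the middle, and its gaps to compound 1 and to compound 3 are both within the scatter, so the three are not separable on this read-out.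

For the measured compounds named here, the only single-point step in the set is a number 2 percentage points higher from compound 1 to compound 2 (within the scatter), which exchanges one aryl group for another on the double-bonded chain carbon bound to a double-bonded chain carbon, and it falls within the scatter.

Compound 4 `COc1cc(OC)c(C(=O)/C=C/c2ccc(F)cc2)c(OC)c1` has not been measured. It differs from compound 2 by 4-fluorophenyl in place of 3-methoxyphenyl on a double-bonded chain carbon bound to a double-bonded chain carbon. This is again an exchange of the aryl group at the same place as the step from compound 1 to compound 2, and that step was within the scatter. The expectation is therefore that the step from compound 2 to compound 4 in this assay is a number 1 percentage points higher from compound 2 to compound 4 (within the scatter), with no change beyond the scatter in either direction. Compound 4 is accordingly estimated at 38% in this assay, within a range from 25% to 52%.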

Compound 4, a percentage reported as activity, at one concentration (the size of the read-out at that concentration, not a potency): 31%
Estimate against measurement, compound 4: 7 percentage points above; the range from low to high includes it.
By their numbers in this assay, from the lowest: compounds 4, 1, 2 and 3 (each within the scatter of the next, the first and the last beyond it).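

In this assay the change to 4-fluorophenyl reads as a number 6 percentage points lower from compound 2 to compound 4 (within the scatter), and against the 2-(methylsulfanyl)phenyl analogue it reads as a number 4 percentage points lower from compound 1 to compound 4 (within the scatter). On the shared core, the place on a double-bonded chain carbon bound to a double-bonded chain carbon now carries three different aryl groups, 2-(methylsulfanyl)phenyl, 3-methoxyphenyl and 4-fluorophenyl, and none separates from another on this read-out. The 4-fluorophenyl group lacks the hydrogen-bond acceptor counted in 3-methoxyphenyl, and it carries neither the oxygen of that group nor the sulfur of 2-(methylsulfanyl)phenyl, yet neither step leaves the scatter, so the read-out at this place does not depend on an oxygen or sulfur atom in the aryl group among these three compounds.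

Still open, on these data alone, is whether any group at this place moves the number beyond the scatter, for example a dimethylamino group or a carboxylic acid on the phenyl ring, or a longer chain in place of the ring. The compounds carry no independent measurement that could explain why these aryl groups read alike.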